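The source may report more compounds than this note shows. Statements on the series, on what has been measured and on what is new or still open speak of the compounds shown alone.

Compounds measured so far:
compound 1, `Cc1cccc(-n2cc(-c3ccccc3NS(=O)(=O)c3c[nH]c(=O)[nH]c3=O)nn2)c1`: 23700 nM
compound 2, `O=c1[nH]cc(S(=O)(=O)Nc2ccccc2-c2cn(-c3ccccc3F)nn2)c(=O)[nH]1`: > 100000 nM
compound 3, `O=c1[nH]cc(S(=O)(=O)Nc2cccc(-c3cn(-c4ccccc4F)nn3)c2)c(=O)[nH]1`: "not toxic" (no number reported)

In an ADME assay on GES1 cells (Homo sapiens) for cytotoxicity, read by MTT assay, with a stated time of 24 h (a lower number here means that less compound is tolerated, a higher number that more compound is tolerated), compound 1 gives 23700 nM. For compound 2 the assay reports only a limit, > 100000 nM, which is the limit of > 100000 nM in this assay, at which 1 of the 3 values shown sits. The change between them is an at least 4.2-fold higher number from compound 1 to compound 2 (0.62 log units; beyond the scatter), so the swap of the aryl group on the aromatic nitrogen moved the number in the direction of more compound being tolerated. Compound 3 is recorded as "not toxic" (no number reported), with no single number given, so it cannot be ranked against the other compounds and can only be read as tolerated in this assay.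

Compound 4, `O=c1[nH]cc(S(=O)(=O)Nc2cccc(-c3cn(-c4ccc(Cl)cc4)nn3)c2)c(=O)[nH]1`, differs from compound 3 by 4-chlorophenyl in place of 2-fluorophenyl on an aromatic nitrogen. Among the compounds with values here, only one measured step bears on this kind of change, the step from compound 1 to compound 2, and it was at least modest; no step compares two halogenated phenyl groups against each other, and compound 3 itself carries no number to step from. The expectation therefore rests on compound 3 being not toxic and on compound 2 sitting at the limit, and it is that compound 4 will again sit at or near the upper edge of this assay. Compound 4 is estimated at 80000 nM, with a range from 25000 nM to 200000 nM.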

Compound 4, half-maximal cytotoxic concentration: 11300 nM
For compound 4 the middle estimate is 7.1-fold (0.85 log units) above the measured one; the measured number lies below the stated range.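

In this assay, within the data shown here, compound 3 is recorded only as ("not toxic" (no number reported)), so no step to compound 4 (11300 nM) can be read. Nothing shown accounts for the value of compound 4. The compounds shown leave open how 4-chlorophenyl and 2-fluorophenyl compare on an aromatic nitrogen when both compounds carry a number.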